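The compounds below may be only part of what the source reports. "The series", "measured", "known", "first", "only" and "open" are said of these compounds alone.

Working notes on the series. Three compounds have numbers in a physicochemical assay for lipophilicity; on this read-out higher numbers stand for higher lipophilicity and lower numbers for lower lipophilicity. Compound 1 `CCCCOC(=O)/C=C(C)/C=C/CC(C)CCCC(C)(C)OC` gives 6.62 in this assay. Compound 3 `CSC(=O)/C=C(C)/C=C/CC(C)CCCC(C)C` gives 7.44, the highest of the three and beyond the scatter above compound 1. Compound 2 `CCOC(=O)/C=C(C)/C=C/CC(C)CCC(O)C(C)C` gives 4.65, the lowest of the three and beyond the scatter below compound 1. Compound 1 thus stands second highest of the three, nearer to compound 3 than to compound 2.

The next compound, compound 4 `CCNC(=O)/C=C(C)/C=C/CC(C)CCCC(C)(C)OC`, has not yet been measured in this assay. It differs from compound 1 in one place: ethylamino in place of butoxy on a carbonyl carbon. For the measured compounds named here, no pair among the three measured compounds shows this same change, so there is no measured step to lean on.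

The expectation is that the step from compound 1 to compound 4 in this assay runs downward and well beyond the scatter, with an estimated size of a number 2.52 log units lower from compound 1 to compound 4 (beyond the scatter). The estimate for compound 4 in this assay is 4.1, with a range from 3.3 to 4.9. Going by the values given here, the range is set wide since no measured pair carries this change. The measurement will show where compound 4 actually falls.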

Compound 4, partition coefficient: 4.04
Beside the measured number, compound 4's estimate is 0.06 log units above it, and the stated range covers the measured number.
By their numbers in this assay, from the lowest: compound 4; then compound 2; then compound 1; then compound 3.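

For the compounds shown here, on the carbonyl carbon, ethylamino in place of butoxy gives a number 2.58 log units lower from compound 1 to compound 4 (beyond the scatter) in this assay, the first step that can be read between two compounds differing in one place. This single step changes two things together: butoxy has 5 heavy atoms and 0 hydrogen-bond donors, whereas ethylamino has 3 heavy atoms and 1 hydrogen-bond donor, and the atom bound to the carbonyl carbon goes from oxygen to nitrogen. Nothing in the data shown gives a reason for the size of this step.

From the compounds shown here alone, it remains open how much of the step goes with the shorter chain and how much with the change from butoxy to an amino group; butylamino on the same carbonyl carbon would keep the carbon count of butoxy and separate the two. Also open, going by these compounds, are how diethylamino, which carries no amide hydrogen, would read at this position and whether a step of this size recurs with the other chain ends.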